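The source may report more compounds than this note shows. Statements on the series, on what has been measured and on what is new or still open speak of the compounds shown alone.

Three compounds were measured in a functional assay on MCF7 cells (Homo sapiens) for antiproliferative activity, read by CellTiter-Glo, with a stated time of 5 days (on this read-out higher numbers stand for weaker inhibition and lower numbers for stronger inhibition), and share a diaryl alkene with an acrylic acid arm and a cyclobutyl group. Compound 1 `N#Cc1ccc(/C(=C(\c2ccc(/C=C/C(=O)O)cc2)c2ccc3scnc3c2)C2CCC2)c(Cl)c1` gives 1.4 nM in this assay. Compound 2 `N#Cc1cc(Cl)ccc1/C(=C(\c1ccc(/C=C/C(=O)O)cc1)c1ccc2scnc2c1)C1CCC1` gives 0.9 nM in this assay. The two are related by one change, (4-chloro-2-cyanophenyl in place of 2-chloro-4-cyanophenyl on a double-bonded chain carbon bound to a double-bonded chain carbon and a saturated ring carbon), which gave a 1.6-fold lower number from compound 1 to compound 2 (0.19 log units; within the scatter). Compound 3 `N#Cc1ccc(/C(=C(\c2ccc(/C=C/C(=O)O)cc2)c2ccc3nccn3c2)C2CCC2)c(Cl)c1` carries a different core: the difference from compound 1 is a group of 9 heavy atoms (7 carbon, 2 nitrogen; one five-membered aromatic ring with 2 hetero atoms, one six-membered aromatic ring with 1 hetero atom) in place of a group of 9 heavy atoms (7 carbon, 1 nitrogen, 1 sulfur; one five-membered aromatic ring with 2 hetero atoms, one six-membered aromatic ring of carbon only), on a double-bonded chain carbon bound to an aromatic carbon and a double-bonded chain carbon, and that change gave an 11-fold higher number from compound 1 to compound 3 (1.03 log units; beyond the scatter). In this assay compound 3 gives 15 nM, the highest number among the three measured compounds.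

Compound 4 `N#Cc1cc(Cl)ccc1/C(=C(\c1ccc(/C=C/C(=O)O)cc1)c1ccc2nccn2c1)C1CCC1` has not yet been measured. It differs from compound 3 by 4-chloro-2-cyanophenyl in place of 2-chloro-4-cyanophenyl on a double-bonded chain carbon bound to a double-bonded chain carbon and a saturated ring carbon, the same change that carried compound 1 to compound 2, at the same place described in the same words. Going by the values given here, the only information on this change comes from the single measured pair, where the step from compound 1 to compound 2 stayed within the scatter; the two cores differ as told above, so whether the change behaves alike on the core of compound 3 is untested. On that basis the step from compound 3 to compound 4 in this assay is expected to be small, a 1.4-fold lower number from compound 3 to compound 4 (0.13 log units; within the scatter), in line with the earlier one. Compound 4 is therefore estimated at 11 nM in this assay, with a likely range from 5 nM to 25 nM.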

Compound 4, half-maximal inhibitory concentration: 5.9 nM
Beside the measured number, compound 4's estimate is 1.9-fold (0.27 log units) above it; measured number inside the range.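

Putting 4-chloro-2-cyanophenyl in place of 2-chloro-4-cyanophenyl on the core of compound 3 gave a 2.5-fold lower number from compound 3 to compound 4 (0.41 log units; beyond the scatter) in this assay, and this step agrees with the earlier one on the core of compound 1, so the change carried over between these two cores within what the measurements can resolve: the same change on two cores in this assay, a 1.6-fold lower number (0.19 log units; within the scatter) from compound 1 to compound 2 and a 2.5-fold lower number (0.41 log units; beyond the scatter) from compound 3 to compound 4, 1.6-fold (0.21 log units) apart, within the scatter of two such steps. The exchange of cores also held up when read on the 4-chloro-2-cyanophenyl compounds, where it gave a 6.6-fold higher number from compound 2 to compound 4 (0.82 log units; beyond the scatter), close to its size on the 2-chloro-4-cyanophenyl compounds: the same change on two cores in this assay, an 11-fold higher number (1.03 log units; beyond the scatter) from compound 1 to compound 3 and a 6.6-fold higher number (0.82 log units; beyond the scatter) from compound 2 to compound 4, 1.6-fold (0.21 log units) apart, within the scatter of two such steps. Going by these compounds alone, this rests on only two pairs, of which one step lies within the scatter and the other beyond it, so it does not show that the change lowers the number in general, nor how it would behave on any third core.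

The compounds shown leave open how the numbers would move with a fluorine or a methyl group in place of the chlorine, or with an ethyl or cyclopentyl group in place of the cyclobutyl group. They also leave open whether the acrylic acid arm could give way to a propanoic acid chain or a primary amide.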